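Swapping Trifluoromethyl for Chloro on the Urea Aryl Ring

The compounds below may be only part of what the source reports. "The series", "measured", "known", "first", "only" and "open" are said of these compounds alone.

Of the compounds shown here, three with a shared core have been tested in a functional assay on NCI-H460 cells (Homo sapiens) for inhibition, read by sulforhodamine B assay, with a stated time of 48 h, tested at 1 uM; on this read-out higher numbers stand for a weaker effect at the one concentration tested and lower numbers for a stronger effect. Compound 1 `O=C(Nc1cccc(-n2cc(-c3ccncc3)c(-c3cc(O)cc(Cl)c3)n2)c1)Nc1ccc(Cl)c(C(F)(F)F)c1` gives 96%. Compound 2 `O=C(Nc1cccc(-n2cc(-c3ccncc3)c(-c3cc(O)cc(Cl)c3)n2)c1)Nc1ccc(Cl)c(Cl)c1` gives 58% in this assay, and compound 3 `COc1cc(Cl)cc(-c2nn(-c3cccc(NC(=O)Nc4ccc(Cl)c(C(F)(F)F)c4)c3)cc2-c2ccncc2)c1` gives 43%. Compound 3 stands lowest of the three numbers, which on this read-out means the strongest effect at the single concentration tested; its nearest number belongs to compound 2 and its furthest to compound 1, both gaps beyond the scatter. Two single changes link the measured compounds: a number 38 percentage points lower from compound 1 to compound 2 (beyond the scatter), and a number 53 percentage points lower from compound 1 to compound 3 (beyond the scatter).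

Compound 4 `COc1cc(Cl)cc(-c2nn(-c3cccc(NC(=O)Nc4ccc(Cl)c(Cl)c4)c3)cc2-c2ccncc2)c1` has not yet been measured. It differs from compound 3 in one place: chloro in place of trifluoromethyl on an aromatic carbon. The very same change has been seen once before, and there it produced a large drop, since a number 38 percentage points lower from compound 1 to compound 2 (beyond the scatter). If that step carries over to compound 3, compound 4 should sit clearly below it in this assay, though a number already near the bottom of the scale has little room left to fall. Compound 4 is therefore estimated at 18%, with a likely range from 2% to 45%. This estimate corresponds to an expected step of a number 25 percentage points lower from compound 3 to compound 4 (beyond the scatter).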

Compound 4, a percentage reported as activity, at one concentration (the size of the read-out at that concentration, not a potency): 77%
Estimate against measurement, compound 4: 59 percentage points below; measured number outside the range, above it.
By their numbers in this assay, from the lowest: compound 3; then compound 2; then compound 4; then compound 1.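

In this assay, the swap of trifluoromethyl for chloro at this position has no fixed direction. With a methyl on the oxygen, it gives a number 34 percentage points higher from compound 3 to compound 4 (beyond the scatter), a weaker effect, while the earlier pair with the free hydroxyl went the other way: the same change on two cores in this assay, a number 38 percentage points lower (beyond the scatter) from compound 1 to compound 2 and a number 34 percentage points higher (beyond the scatter) from compound 3 to compound 4, 72 percentage points apart, beyond the scatter of two such steps

The methyl on the oxygen behaves the same way, since with the 3,4-dichlorophenyl group in place it gives a number 19 percentage points higher from compound 2 to compound 4 (beyond the scatter), also a weaker effect, instead of the stronger effect seen with the 4-chloro-3-(trifluoromethyl)phenyl group: the same change on two cores in this assay, a number 53 percentage points lower (beyond the scatter) from compound 1 to compound 3 and a number 19 percentage points higher (beyond the scatter) from compound 2 to compound 4, 72 percentage points apart, beyond the scatter of two such steps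

Across these four compounds, then, the two changes do not simply add up, and the outcome of each depends on what the other site carries, so a step measured on one core cannot safely be carried over to the other.

The compounds shown leave open why the two sites depend on each other, and a read-out at one concentration gives no potency for any of them. A bromo or a methyl in place of the trifluoromethyl, or an ethyl on the oxygen, would show whether this dependence extends beyond the groups seen here.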